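A Methoxy Added to a Phenylethyl Amide at the Limit

The source may report more compounds than this note shows. Statements on the series, on what has been measured and on what is new or still open speak of the compounds shown alone.

compound 1 `CCCCNc1nc(N)nc2cccc(C(=O)NC(C)C)c12`: 15.6 uM
compound 2 `CCCCNc1nc(N)nc2cccc(C(=O)NCc3ccccc3)c12`: 1.6 uM
compound 3 `CCCCNc1nc(N)nc2cccc(C(=O)N[C@@H](C)c3ccccc3)c12`: > 25 uM

All three share one core and differ only in the group on the amide nitrogen, and all were measured in an ADME assay on HEK293 cells for agonist activity at Toll-like receptor 8 (Homo sapiens), read by a luciferase reporter, with a stated time of 6 h; on this read-out higher numbers stand for an effect only at larger amounts of compound and lower numbers for an effect already at smaller amounts. Compound 2 carries a benzyl group and gives the lowest number of the three, with a 9.8-fold lower number from compound 1 to compound 2 (0.99 log units; beyond the scatter). Compound 3 carries a 1-phenylethyl group and sits at the limit of this assay, (the limit of > 25 uM in this assay, at which 1 of the 3 values shown sits), so only a floor is known for it. The two steps leading to compound 3 read an at least 1.6-fold higher number from compound 1 to compound 3 (0.20 log units; that floor lies within the scatter) and an at least 15-fold higher number from compound 2 to compound 3 (1.19 log units; beyond the scatter).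

Compound 4, `CCCCNc1nc(N)nc2cccc(C(=O)N[C@@H](C)c3ccccc3OC)c12`, is compound 3 with a methoxy in place of hydrogen on an aromatic carbon. Going by the values given here, no measured step alters a substituent on the phenyl ring, so none bears directly on this change. What is known is that, with methyl in place of hydrogen on the chain carbon, the step of an at least 15-fold higher number from compound 2 to compound 3 (1.19 log units; beyond the scatter) ends at the limit, and a methoxy on the ring gives no measured reason to expect a return to measurable numbers. Compound 4 is therefore expected to stay near or at the limit, estimated at 30 uM with a range from 8 uM to 120 uM, which means an expected step that the limit leaves unreadable from compound 3 to compound 4 that does not exceed the scatter.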

Compound 4, minimum effective concentration: > 25 uM
Compound 4: a limit, no number; the forecaster's own chance of this, stated with the estimate: 60%; the middle value lies beyond the limit too.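

In this assay compound 4 gives > 25 uM, which is a limit and not a number. Compound 3 stands at the same limit, so the step from compound 3 to compound 4 cannot be read: the limit of > 25 uM in this assay, at which 2 of the 4 values shown sit.

The compounds shown leave open what methoxy in place of hydrogen does on a phenyl ring whose amide gives a measurable value, such as compound 2.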